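The compounds below may be only part of what the source reports. "The series", "measured", "known", "first", "only" and "open" are said of these compounds alone.

Measured compounds: compound 1 `Cc1cc(C)cc(S(=O)(=O)c2c(C(=O)NC3CC4(CCN(C(=O)OC(C)(C)C)C4)C3)[nH]c3ccc(Cl)cc23)c1` gives 171000 nM in a toxicity assay on MT4 cells (Homo sapiens) for cytotoxicity, read by MTT assay, with a stated time of 7 days; on this read-out higher numbers stand for lower toxicity in this test and lower numbers for higher toxicity in this test; compound 2 `Cc1cc(C)cc(S(=O)(=O)c2c(C(=O)NC3CC4(CCN(CC(N)=O)C4)C3)[nH]c3ccc(Cl)cc23)c1` gives 3700 nM; compound 3 `Cc1cc(C)cc(S(=O)(=O)c2c(C(=O)NC3CC4(CCN(CC(N)=O)CC4)C3)[nH]c3ccc(Cl)cc23)c1` gives 3610 nM.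

Compound 1 differs from compound 2 by tert-butoxycarbonyl in place of carbamoylmethyl on an amine nitrogen in a ring, and that step is a 46-fold higher number from compound 2 to compound 1 (1.66 log units; beyond the scatter). Compound 4 `Cc1cc(C)cc(S(=O)(=O)c2c(C(=O)NC3CC4(CCN(C(=O)OC(C)(C)C)CC4)C3)[nH]c3ccc(Cl)cc23)c1` is not yet measured; it differs from compound 3 by tert-butoxycarbonyl in place of carbamoylmethyl on an amine nitrogen in a ring. How the cores of compound 3 and compound 2 differ is not broken down here. The two changes are of the same kind but not the same: in compound 2 the amine nitrogen sits in a five-membered non-aromatic ring, in compound 3 in a six-membered one. Compound 3 and compound 2 give numbers within the scatter of each other. The step from compound 3 to compound 4 is expected to be a 42-fold higher number from compound 3 to compound 4 (1.62 log units; beyond the scatter), because the same kind of change gave a 46-fold higher number from compound 2 to compound 1 (1.66 log units; beyond the scatter) in this assay. Compound 4 is therefore estimated at 150000 nM, expected between 50000 nM and 400000 nM.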

Compound 4, half-maximal cytotoxic concentration: 133000 nM
Compound 4: middle estimate off by 1.1-fold (0.05 log units), on the high side; the range from low to high includes it.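

Putting tert-butoxycarbonyl in place of carbamoylmethyl on an amine nitrogen in a ring gave a 37-fold higher number from compound 3 to compound 4 (1.57 log units; beyond the scatter) in this assay. Set beside the earlier step, the change carried from the core with the five-membered ring to the core with the six-membered ring at much the same size: the same change on two cores in this assay, a 46-fold higher number (1.66 log units; beyond the scatter) from compound 2 to compound 1 and a 37-fold higher number (1.57 log units; beyond the scatter) from compound 3 to compound 4, 1.3-fold (0.10 log units) apart, within the scatter of two such steps. Going by these compounds alone, this rests on only two pairs and a single change, so it shows that the step held on these two cores, but not that it would hold on other cores, and it does not show why the step is so large.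

On these data alone, it remains open where other groups on this nitrogen, such as acetyl or a longer chain ending in a carboxylic acid, would fall in this assay. As far as these compounds go, whether the free amine would stand nearer compound 3 or compound 4 is also open.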